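A few compounds are considered here, and "the series" means these few. Any claim that something is new, unique, unknown or untested is made for them only; others in the source may bear on it.

Compound 1, `COc1cccc(-c2nc3c(-c4ccc(Cl)cc4)n[nH]c3c(=O)n2NC(=O)c2ccccc2)c1`, gives 94.1% in a functional assay on DU-145 cells (Homo sapiens) for cytotoxicity, read by sulforhodamine B assay, with a stated time of 2 days, tested at 100 uM; a higher number here means more inhibition at the concentration tested (going by the name of the read-out), a lower number less inhibition.
Compound 2, `O=C(Nn1c(-c2ccccc2)nc2c(-c3ccc(Cl)cc3)n[nH]c2c1=O)c1ccccc1`, gives 90.2% in this assay.
Compound 3, `O=C(Nn1c(CCc2ccccc2)nc2c(-c3ccc(Cl)cc3)n[nH]c2c1=O)c1ccccc1`, gives 85.6% in this assay.

All three share the same core and a benzoyl-bearing amide, and differ only in the group on one aromatic carbon of that core. Compound 3 carries a phenethyl there and has the lowest of the three numbers, but its gaps to the others are small: a number 4.6 percentage points lower from compound 2 to compound 3 (within the scatter), and a number 8.5 percentage points lower from compound 1 to compound 3 (within the scatter). Within the usual scatter, then, the three compounds cannot be told apart.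

Compound 4, `CCCc1nc2c(-c3ccc(Cl)cc3)n[nH]c2c(=O)n1NC(=O)c1ccccc1`, continues along the same chain. The change is methyl in place of phenyl on a saturated chain carbon, two bonds along the chain from an aromatic carbon, so that the phenethyl of compound 3 becomes a propyl in compound 4, and an aromatic ring is lost.

Going by the values given here, the steps that bear on this are the ones at the same position: a number 8.5 percentage points lower from compound 1 to compound 3 (within the scatter) and a number 4.6 percentage points lower from compound 2 to compound 3 (within the scatter), both within the scatter, as is a number 3.9 percentage points lower from compound 1 to compound 2 (within the scatter). Three rather different groups at that carbon have thus given much the same number. Because those steps were all within the scatter, compound 4 is expected to show a number 5.6 percentage points lower from compound 3 to compound 4 (within the scatter), that is, no step beyond the scatter, though the loss of the ring adds some uncertainty. Compound 4 is therefore estimated at 80%, within a range from 55% to 95%.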

Compound 4, a percentage reported as inhibition, at one concentration (the size of the read-out at that concentration, not a potency): 89.4%
Estimate against measurement, compound 4: 9.4 percentage points below, and the stated range covers the measured number.
By their numbers in this assay, from the lowest: compounds 3, 4, 2 and 1 (each within the scatter of the next).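

Replacing phenyl with methyl on the saturated chain removes the only aromatic ring from this group, yet the result in this assay stays within the scatter (a number 3.8 percentage points higher from compound 3 to compound 4 (within the scatter)). Every earlier compound carried an aromatic ring in this group, so they could not show whether a ring was needed here; compound 4 has only a plain propyl chain, and it also cannot be told apart from the compounds with a ring attached directly to the core (a number 0.8 percentage points lower from compound 2 to compound 4 (within the scatter); a number 4.7 percentage points lower from compound 1 to compound 4 (within the scatter)). Across these four compounds, then, neither the ring nor its distance from the core separates the results, and no measurement here explains why.

The compounds shown leave open what an amine, a carboxylic acid, a longer chain or a single methyl at this carbon of the shared core would give. Going by these compounds, because each result comes from one high concentration, it also remains open whether these four compounds would separate at lower concentrations.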